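Swapping phenyl for methoxycarbonyl on a shared core

A few compounds are considered here, and "the series" means these few. Any claim that something is new, unique, unknown or untested is made for them only; others in the source may bear on it.

Measured in a functional assay on MCF7 cells (Homo sapiens) for cytotoxicity, read by MTT assay, with a stated time of 72 h; a lower number here means a stronger inhibitor, a higher number a weaker inhibitor:
- Compound 1 `NCCNc1c(C(=O)NCc2ccc(F)cc2)nc(Br)c2cccnc12`: 6000 nM
- Compound 2 `O=C(NCc1ccc(F)cc1)c1nc(Br)c2cccnc2c1NCc1ccccc1`: "not determined" (no result reported)

Compound 2 has no standing on the numbers, since no result was reported for it in this assay. Going by the values given here, the series therefore offers only one measured value: sharing its core with compound 2 but having a different chain on the nitrogen, compound 1 gives 6000 nM.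

Compound 3 `COC(=O)CNc1c(C(=O)NCc2ccc(F)cc2)nc(Br)c2cccnc12` has yet to be measured. The structural change methoxycarbonyl in place of phenyl on a saturated chain carbon bound to a nitrogen on an aromatic ring puts methoxycarbonyl in place of phenyl on a saturated chain carbon bound to a nitrogen on an aromatic ring.

Among the compounds with values here, without a number for compound 2, no step from it can be sized. Within the data shown here, the only guide in this assay is compound 1 at 6000 nM, so a modest step towards weaker inhibition relative to that value is expected. For compound 3 the estimated value is 15000 nM, with an expected range of 5000 nM to 50000 nM.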

Compound 3, half-maximal inhibitory concentration: > 10000 nM
Compound 3 was reported as a limit; the forecaster's own chance of this, stated with the estimate: 25%; the middle value is on the limit's open side.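

In this assay compound 3 gives > 10000 nM as its result, and this is a limit of the assay, not a number. Methoxycarbonyl in place of aminomethyl on a saturated chain carbon bound to a nitrogen on an aromatic ring gives an at least 1.6-fold higher number from compound 1 to compound 3 (0.22 log units; that floor lies within the scatter) as the first step that can be stated at this position. This step shows no clear loss on its own, and its true size stays unknown because the reading ends at a limit: the limit of > 10000 nM in this assay, at which 1 of the 3 values shown sits.

The step from compound 2 cannot be read, so the change from phenyl to methoxycarbonyl remains unsized. Also open, from the compounds shown here alone, is what a carboxylic acid, or a longer chain ending in an amine, would do on the same saturated chain carbon.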